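The source may report more compounds than this note shows. Statements on the series, on what has been measured and on what is new or still open speak of the compounds shown alone.

In a functional assay on HT-29 cells (Homo sapiens) for inhibition, read by sulforhodamine B assay, with a stated time of 48 h (on this read-out higher numbers stand for weaker inhibition of growth and lower numbers for stronger inhibition of growth), compound 1 `CC1(/C=C/c2ccccc2)C=CC(=O)O1` gives 123000 nM, at the high end of the measured numbers and within the scatter of compound 3 `CC1(/C=C/c2cccc(O)c2)C=CC(=O)O1` at 97400 nM. Compound 2 `CC1(/C=C/c2ccccc2O)C=CC(=O)O1` gives 31300 nM. Compound 4 `CC1(/C=C/c2ccc(O)cc2)C=CC(=O)O1` differs from compound 1 by hydroxy in place of hydrogen on an aromatic carbon. Two measured steps make the same kind of replacement at other places on the ring: a 3.9-fold lower number from compound 1 to compound 2 (0.59 log units; beyond the scatter), and a 1.3-fold lower number from compound 1 to compound 3 (0.10 log units; within the scatter). Neither raises the number, so a small step towards a lower number is expected in this assay, possibly none beyond the scatter. The estimated step is a 1.8-fold lower number from compound 1 to compound 4 (0.24 log units; within the scatter). For compound 4 the expected value is 70000 nM, with an estimated range from 28000 nM to 130000 nM.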

Compound 4, concentration for total growth inhibition: 122000 nM
For compound 4 the middle estimate is 1.7-fold (0.24 log units) below the measured one, within the range that was stated.
By their numbers in this assay, from the lowest: compound 2; then compounds 3, 4 and 1 (each within the scatter of the next).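

With hydroxy on an aromatic carbon para to a group of 9 heavy atoms, the replacement leaves the number in this assay where it was, with a 1.0-fold lower number from compound 1 to compound 4 (0.00 log units; within the scatter). Of the three placements shown, only a 3.9-fold lower number from compound 1 to compound 2 (0.59 log units; beyond the scatter) lies beyond the scatter, so the gain from hydroxy belongs to that one place and is not shared by compound 3 or compound 4. Nothing given here accounts for this dependence on place. Still open, from the compounds shown here alone, is whether a methoxy group or an amine on the ring of compound 2, in the place of its hydroxy, would keep the lower number.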